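The source may hold more compounds than are shown below. What is called first, only, known or untested is meant among the compounds shown, and "the series" means these compounds.

In a functional assay on M21 cells (Homo sapiens) for antiproliferative activity, read by sulforhodamine B assay, with a stated time of 48 h; a higher number here means a weaker inhibitor, a lower number a stronger inhibitor:
compound 1 `CCN1CCN(c2ccc(S(=O)(=O)Oc3cccc(F)c3)cc2)C1=O` gives 11000 nM
compound 2 `CCCN1CCN(c2ccc(S(=O)(=O)Oc3ccccc3OC)cc2)C1=O` gives > 100000 nM
compound 3 `CCCN1CCN(c2ccc(S(=O)(=O)Oc3cccc(C)c3)cc2)C1=O` gives 28000 nM

The result of compound 2 (> 100000 nM) is a limit and not a number. Of the two true numbers, compound 3 (28000 nM) holds the higher, and its gap to compound 1 (11000 nM) lies beyond the scatter.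

Compound 4 `CCCN1CCN(c2ccc(S(=O)(=O)Oc3cccc(F)c3)cc2)C1=O` differs from compound 3 by fluoro in place of methyl on an aromatic carbon, turning 3-methylphenyl into 3-fluorophenyl (fluoro in place of methyl on an aromatic carbon). Among the compounds with values here, the only measured step is an at least 3.5-fold lower number from compound 2 to compound 3 (0.55 log units; beyond the scatter) and it starts from a limit and exchanges a different group, so it says little about size here. Compound 1 (11000 nM) already carries 3-fluorophenyl, with ethyl in place of propyl, which points to a slightly lower number or to no change beyond the scatter. The expected step (a 1.6-fold lower number from compound 3 to compound 4 (0.19 log units; within the scatter)) is therefore small. For compound 4 the estimated value is 18000 nM (expected range 7000 nM to 45000 nM).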

Compound 4, half-maximal inhibitory concentration: 12000 nM
Beside the measured number, compound 4's estimate is 1.5-fold (0.18 log units) above it; measured number inside the range.
By their numbers in this assay, from the lowest: compounds 1 and 4 (each within the scatter of the next); then compound 3. At a limit, above all of these: compound 2.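

In this assay, within the data shown here, fluoro in place of methyl on this aromatic carbon gives a 2.3-fold lower number from compound 3 to compound 4 (0.37 log units; beyond the scatter), the first measured change of this one group alone. With 3-fluorophenyl kept, ethyl and propyl cannot be told apart: a 1.1-fold higher number from compound 1 to compound 4 (0.04 log units; within the scatter). The remaining step, an at least 8.3-fold lower number from compound 2 to compound 4 (0.92 log units; beyond the scatter), starts from a limit rather than a number, so it gives only a minimum size: the limit of > 100000 nM in this assay, at which 1 of the 4 values shown sits.

On these data alone, whether chloro or an amine on this same carbon would give a lower number remains open. So does the effect of a longer chain, such as butyl, in place of propyl.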